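Isopropyl addition on the methylsulfonylphenyl ring of compound 2

A few compounds are considered here, and "the series" means these few. Any claim that something is new, unique, unknown or untested is made for them only; others in the source may bear on it.

Measured so far:
compound 1 `CC(C)c1ccc(S(C)(=O)=O)cc1C#Cc1cc(C#N)ccc1OCC(=O)O`, 12 nM
compound 2 `CS(=O)(=O)c1cccc(C#Cc2cc(Cl)ccc2OCC(=O)O)c1`, 15 nM

Two compounds have been run in an assay on CHO cells for displacement of a labelled ligand from prostaglandin D2 receptor 2 (Homo sapiens), read by scintillation counting; on this read-out higher numbers stand for weaker inhibition and lower numbers for stronger inhibition. Compound 1 gives 12 nM and compound 2 gives 15 nM. Compound 2 holds the higher of the two numbers, but the gap to compound 1 is within the scatter, so the two values show no difference that can be read as an order.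

Compound 3 `CC(C)c1ccc(S(C)(=O)=O)cc1C#Cc1cc(Cl)ccc1OCC(=O)O` is the next compound to be measured. Relative to compound 2 the change is isopropyl in place of hydrogen on an aromatic carbon, ortho to a large group and para to the methylsulfonyl group. The remainder of the molecule, including the chloro substituent and the acid side chain, is unchanged.

Among the compounds with values here, no pair of measured compounds differs in this one place alone, so there is no step to lean on. Compound 1 carries the same isopropyl group and gives 12 nM, and compound 2 without it gives 15 nM; the two values lie within the scatter of each other, with a different substituent also in play. The expectation is therefore a step from compound 2 to compound 3 of no size beyond the scatter, with a 1.5-fold lower number from compound 2 to compound 3 (0.18 log units; within the scatter) as the estimated change, tending if anything toward a lower number in this assay. For compound 3 the estimate in this assay is 10 nM, expected to fall between 4 nM and 25 nM.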

Compound 3, inhibition constant: 4.6 nM
Estimate against measurement, compound 3: 2.2-fold (0.34 log units) above, within the range that was stated.
By their numbers in this assay, from the lowest: compound 3; then compounds 1 and 2 (each within the scatter of the next).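

In this assay this aromatic carbon, ortho to a large group and para to a methylsulfonyl group, is a position where substitution registers: with the chloro substituent held fixed, isopropyl in place of hydrogen gives a 3.3-fold lower number from compound 2 to compound 3 (0.51 log units; beyond the scatter) and so moves the number beyond the scatter. With the isopropyl group held fixed, chloro in place of cyano on an aromatic carbon gives a 2.6-fold lower number from compound 1 to compound 3 (0.42 log units; beyond the scatter) and shows that this second place also counts, something the close values of compound 1 and compound 2 could not show, since those two differ in two places at once. No measurement in hand gives a reason for either step.

Open, from the compounds shown here alone, is whether the isopropyl step depends on the chloro substituent, which would take the matching compound with cyano and hydrogen in these two places to settle. Also open, going by these compounds, is how much of the step is specific to isopropyl, which a methyl, a tert-butyl or a methoxy group on the same aromatic carbon would test.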